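Hydroxymethylpropyl in Place of Butyl on the Ring Nitrogen

The source may report more compounds than this note shows. Statements on the series, on what has been measured and on what is new or still open speak of the compounds shown alone.

Among the measured compounds shown here, compound 2 `CCCCN1C(=O)NC2(CC2(C)C)C1=O` gives 30% in a functional assay on the whole organism for inhibition, with Mus musculus as the target, at a dose of 20 mg/kg by the oral route (a lower number here means a weaker effect, a higher number a stronger effect of the compound at the dose given), and stands at the top of the two numbers measured so far, though its gap to compound 1 `CN1C(=O)NC2(CC2(C)C)C1=O`, which in this assay gives 20%, lies within the scatter. For the measured compounds named here, the only recorded step on the nitrogen of the shared core is a number 10 percentage points higher from compound 1 to compound 2 (within the scatter). Compound 3 `CCC(CO)N1C(=O)NC2(CC2(C)C)C1=O` differs from compound 2 by 1-(hydroxymethyl)propyl in place of butyl on an amide-type nitrogen in a ring. Going by the values given here, no measured pair shows what the 1-(hydroxymethyl)propyl chain does at this position, so the single recorded step, itself within the scatter, is the only guide, and it offers no reason to expect a step beyond the scatter in either direction. The inhibition of compound 3 in this assay is therefore estimated at 30%, within a range of 10% to 50%. The step of no change at the digits printed from compound 2 to compound 3 (within the scatter) is thus expected to remain within the scatter.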

Compound 3, a percentage reported as inhibition, in the whole organism at one dose (the size of the read-out at that dose, not a potency): 20%
The estimate for compound 3 lay 10 percentage points above the measured number; low and high end bracket the measured number.
By their numbers in this assay, from the lowest: compounds 1, 3 and 2 (each within the scatter of the next).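

In this assay, among the compounds shown here, 1-(hydroxymethyl)propyl is the first chain on this amide-type nitrogen to carry a hydrogen-bond donor and a hydrogen-bond acceptor, and the change gives a number 10 percentage points lower from compound 2 to compound 3 (within the scatter) and no change at the digits printed from compound 1 to compound 3 (within the scatter). The methyl, butyl and 1-(hydroxymethyl)propyl chains at this position therefore all give numbers within the scatter of one another at this single oral dose, so none of the three can be ranked above another. No supporting data bear on the reason for this outcome.

The compounds shown do not separate the branching of the chain from its hydroxyl, since no plain branched chain such as sec-butyl stands beside compound 3. They also leave open whether an amine, a carboxylic acid or a longer chain on this nitrogen would give a step beyond the scatter.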